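The source may hold more compounds than are shown below. What is called first, only, known or untested is meant among the compounds shown, and "the series" means these compounds.

The set comprises two measured compounds and one whose number is still to come. Compound 1 `C/C(=C\c1cc(-c2ccccc2)cs1)C(N)=O` was tested in a functional assay on HeLa cells (Homo sapiens) for cytotoxicity, read by CCK-8 assay, with a stated time of 24 h (a higher number here means a weaker inhibitor, a lower number a stronger inhibitor), where compound 1 gives 12700 nM. Going by the values given here, compound 2 `C/C(=C\c1cccc(-c2ccc(C)cc2)c1)C(N)=O` is the only other compound with a number in this assay; in that assay compound 2 gives 24800 nM, a value that lies within the scatter of the value of compound 1, so the two cannot be told apart with confidence. Among the compounds with values here, compound 1 thus has the lowest of the two numbers recorded, but without separation from its one neighbour. Within the data shown here, no pair of measured compounds differs in only one place, so no measured step is available to guide an expectation. Among the measured compounds shown here, compound 3 `C=Cc1ccc(-c2csc(/C=C(\C)C(N)=O)c2)cc1` is related to compound 1 by a single change: vinyl in place of hydrogen on an aromatic carbon Nothing among the measured compounds speaks to this change, and the expected step is small, in no particular direction, and within the scatter: a 1.1-fold lower number from compound 1 to compound 3 (0.02 log units; within the scatter). Compound 3 is therefore estimated to give 12000 nM in this assay, with a range from 5000 nM to 30000 nM.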

Compound 3, half-maximal inhibitory concentration: > 50000 nM
Compound 3: only a limit was reported; the forecaster's own chance of this, stated with the estimate: 10%; middle value at least 4.1-fold (0.61 log units) from the limit.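

In this assay, the set now has its first measured step: vinyl in place of hydrogen on an aromatic carbon, para to a large group, gives an at least 3.9-fold higher number from compound 1 to compound 3 (0.59 log units; beyond the scatter). Going by these compounds alone, this shows that the position is not indifferent to substitution, since adding this group of 2 heavy atoms to compound 1 produces a change that is beyond the scatter and makes the compound a weaker inhibitor, something that the earlier compounds, with no step between them, could not show. The reading for compound 3 is a limit and not a number, so the step has a floor but no known full size: the limit of > 50000 nM in this assay, at which 1 of the 3 values shown sits.

Going by these compounds, with a single group at this position, it remains open whether the loss belongs to vinyl in particular or to any substitution there, and an ethyl chain, an amine or a carboxylic acid in the same place would help to separate these possibilities. Compound 2 differs from compound 1 and compound 3 in more than one place, so it cannot settle this question, and the compounds shown offer no cause for the step.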